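The compounds below may be only part of what the source reports. "The series", "measured", "known", "first", "only" and "open" are said of these compounds alone.

Measured so far:
compound 1 `N#Cc1ccccc1-c1cnc(C(=O)CCCCCCc2ccccc2)o1` gives 130 nM in an assay (Rattus norvegicus) for inhibition of Fatty-acid amide hydrolase 1 (Homo sapiens); a lower number here means a stronger inhibitor, a higher number a weaker inhibitor;
compound 2 `NS(=O)(=O)c1ccc(-c2cnc(C(=O)CCCCCCc3ccccc3)o2)cc1` gives 10 nM in this assay.

Compound 1 stands at the highest number of the two; compound 2 lies a long way lower, beyond the scatter. Compound 3 `N#Cc1ccc(-c2cnc(C(=O)CCCCCCc3ccccc3)o2)cc1` is not yet measured. It differs from compound 1 by 4-cyanophenyl in place of 2-cyanophenyl on an aromatic carbon. Among the compounds with values here, no measured pair shows this change. A moderate step down is expected for a 2.9-fold lower number from compound 1 to compound 3 (0.46 log units; beyond the scatter), since compound 2 also carries its group in the 4-position and gives 10 nM. Compound 3 is estimated at 45 nM, between 12 nM and 170 nM.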

Compound 3, inhibition constant: 40 nM
For compound 3 the middle estimate is 1.1-fold (0.05 log units) above the measured one; low and high end bracket the measured number.
By their numbers in this assay, from the lowest: compound 2; then compound 3; then compound 1.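

Working from this assay, 4-cyanophenyl in place of 2-cyanophenyl, with the same atoms joined differently, changes the number (modest step: a 3.3-fold lower number from compound 1 to compound 3 (0.51 log units; beyond the scatter)), so where the nitrile sits on this substituent matters. With that placement held, cyano in place of sulfamoyl also counts (modest step: a 4.0-fold higher number from compound 2 to compound 3 (0.60 log units; beyond the scatter)). No measurement offered here explains either step. Still open, on these data alone, is whether the difference between 2-cyanophenyl and 4-cyanophenyl carries over to sulfamoyl, and how a carboxylic acid or an amine would read in place of cyano.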